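The source may report more compounds than this note shows. Statements on the series, on what has been measured and on what is new or still open speak of the compounds shown alone.

Measured in a functional assay on M21 cells (Homo sapiens) for antiproliferative activity, read by sulforhodamine B assay, with a stated time of 48 h; on this read-out lower numbers stand for stronger inhibition of growth and higher numbers for weaker inhibition of growth:

Compound 1, `CCCCc1ccc(-c2cc(N3CCC(CNS(N)(=O)=O)CC3)ncn2)cc1`, gives 47200 nM.
Compound 2, `COc1ccc(-c2cc(N3CCC(CNS(N)(=O)=O)CC3)ncn2)cc1`, gives > 100000 nM, which is a limit of the assay and not a number.
Compound 3, `NS(=O)(=O)NCC1CCN(c2cc(-c3ccc(C(F)(F)F)cc3)ncn2)CC1`, gives 43100 nM.

Compound 3 carries the lowest of the two numbers that exist in this assay, but its neighbour compound 1 sits within the scatter: a 1.1-fold lower number from compound 1 to compound 3 (0.04 log units; within the scatter). Compound 2 stands apart only as a limit (the limit of > 100000 nM in this assay, at which 1 of the 3 values shown sits).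

Compound 4 is `CCOC(=O)c1ccc(-c2cc(N3CCC(CNS(N)(=O)=O)CC3)ncn2)cc1`, not yet measured. It differs from compound 3 by ethoxycarbonyl in place of trifluoromethyl on an aromatic carbon.

The measured steps that touch the same aromatic carbon are an at least 2.1-fold higher number from compound 1 to compound 2 (0.32 log units; beyond the scatter) and an at least 2.3-fold lower number from compound 2 to compound 3 (0.36 log units; beyond the scatter). Both involve methoxy and show that a change at this position can move the number beyond the scatter, while a 1.1-fold lower number from compound 1 to compound 3 (0.04 log units; within the scatter) shows that two other groups there are interchangeable. Going by the values given here, no measured step involves ethoxycarbonyl, so its direction is open; on the two larger groups, a step near the scatter is the safer expectation, with the limit kept in view.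

Compound 4 is therefore expected at about 60000 nM in this assay, between 20000 nM and 200000 nM, which means an estimated step of a 1.4-fold higher number from compound 3 to compound 4 (0.14 log units; within the scatter).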

Compound 4, concentration for 50% growth inhibition: 5000 nM
Compound 4: middle estimate off by 12-fold (1.08 log units), on the high side; the whole stated range lies above it.
By their numbers in this assay, from the lowest: compound 4; then compounds 3 and 1 (each within the scatter of the next). At a limit, above all of these: compound 2.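

In this assay, ethoxycarbonyl is the only group shown at this aromatic carbon that brings the number clearly below the level shared by butyl and trifluoromethyl, with an 8.6-fold lower number from compound 3 to compound 4 (0.94 log units; beyond the scatter) and a 9.4-fold lower number from compound 1 to compound 4 (0.97 log units; beyond the scatter). Going by these compounds alone, the earlier compounds showed only that compound 1 and compound 3 could not be told apart and that methoxy in compound 2 gave a weaker result, whereas this position can now be seen to respond in the direction of stronger inhibition of growth as well. The comparison with methoxy gives an at least 20-fold lower number from compound 2 to compound 4 (1.30 log units; beyond the scatter), but the value of compound 2 is a limit and not a number, so the true size of this step stays open: the limit of > 100000 nM in this assay, at which 1 of the 4 values shown sits.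

The compounds shown do not separate the contributions of the carbonyl, the ethyl part and the two hydrogen-bond acceptors that enter with ethoxycarbonyl, and a methyl ester, a primary amide or a carboxylic acid on the same carbon would address that question. They also leave open whether the lower number depends on this group staying para to the large group or would carry over to other placements on the ring.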